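The compounds below may be only part of what the source reports. "The series", "measured", "known", "first", "only" and "open" are said of these compounds alone.

Working notes on the series, all read in a functional assay on HepG2 cells (Homo sapiens) for antiproliferative activity, read by MTT assay, with a stated time of 48 h; on this read-out higher numbers stand for weaker inhibition of growth and lower numbers for stronger inhibition of growth. Compound 2 (`COC(=O)N1N=C(c2cccc(OC)c2)CC1c1cc(OC)c(OC)c(OC)c1`) gives 1870 nM. Compound 3 (`CCCOC(=O)N1N=C(c2cccc(OC)c2)CC1c1cc(OC)c(OC)c(OC)c1`) returns only a limit, > 10000 nM. Compound 1 (`COc1cc(C2CC(c3ccccc3)=NN2C(=O)OCc2ccccc2)cc(OC)c1OC`) likewise returns only a limit, > 10000 nM. Going by these compounds, compound 3 therefore sits at the limit of > 10000 nM in this assay, at which 2 of the 3 values shown sit, and its true value is unknown.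

Compound 4 (`COc1cccc(C2=NN(C(=O)OCc3ccccc3)C(c3cc(OC)c(OC)c(OC)c3)C2)c1`) follows from compound 3 by phenyl in place of ethyl on a saturated chain carbon bound to an oxygen next to a carbonyl group, so that propoxycarbonyl becomes benzyloxycarbonyl.

Within the data shown here, the one measured step at this place is an at least 5.3-fold higher number from compound 2 to compound 3 (0.72 log units; beyond the scatter), beyond the scatter and towards weaker inhibition of growth. Compound 1 already carries benzyloxycarbonyl and shows no measurable value, > 10000 nM being a limit. No recovery towards compound 2 is therefore expected, and no clear move beyond the scatter is expected either. The expected step is a step that the limit leaves unreadable from compound 3 to compound 4, and a further limit is the likeliest report. For compound 4 the estimated value is 12000 nM, with an expected range of 4000 nM to 40000 nM.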

Compound 4, concentration for 50% growth inhibition: > 10000 nM
Compound 4 gave a limit, no number; the forecaster's own chance of this, stated with the estimate: 70%; the middle value does not contradict the limit.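

In this assay compound 4 also gives only a limit, > 10000 nM. On a saturated chain carbon bound to an oxygen next to a carbonyl group, phenyl in place of hydrogen gives an at least 5.3-fold higher number from compound 2 to compound 4 (0.72 log units; beyond the scatter), so the loss seen with ethyl at this place also appears with phenyl. Neither phenyl in place of ethyl nor methoxy in place of hydrogen on an aromatic carbon brings back a measurable value, and the steps from compound 3 and from compound 1 to compound 4 cannot be read because both ends of each are limits: the limit of > 10000 nM in this assay, at which 3 of the 4 values shown sit.

Going by these compounds, how far compound 1, compound 3 and compound 4 lie from one another stays open, since none has a number. Also open, on these data alone, is whether ethoxycarbonyl, or a chain ending in an amine or a carboxylic acid, would stay near compound 2 at this place.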